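The source may report more compounds than this note shows. Statements on the series, on what has been measured and on what is new or still open speak of the compounds shown alone.

Measured so far:

- compound 1, `CC(C)=CCOc1ccc2c(c1)OC(c1ccc(Cl)cc1)CC2=O` — 6970 nM
- compound 2, `CC(C)=CCOc1ccc2c(c1)OC(c1ccc(Cl)cc1Cl)CC2=O` — 5260 nM
- compound 3, `CC(C)=CCOc1cc(O)c2c(c1)OC(c1ccc(Cl)cc1)CC2=O` — 7020 nM

All three were tested in a functional assay; a lower number here means a stronger inhibitor, a higher number a weaker inhibitor. Compound 2 differs from compound 1 in one place: chloro in place of hydrogen on an aromatic carbon. The resulting step was a 1.3-fold lower number from compound 1 to compound 2 (0.12 log units; within the scatter), so the two compounds cannot be told apart by this measurement. Compound 3 differs from compound 1 in a different place: hydroxy in place of hydrogen on an aromatic carbon. Here too the step, a 1.0-fold higher number from compound 1 to compound 3 (0.00 log units; within the scatter), lies within the scatter, and compound 3 and compound 2 are likewise within the scatter of each other. The three numbers therefore sit close together, with no ordering that the data can support.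

Compound 4, `CC(C)=CCOc1cc(O)c2c(c1)OC(c1ccc(Cl)cc1Cl)CC2=O`, has not yet been measured. It stands to compound 3 as compound 2 stands to compound 1: the difference is chloro in place of hydrogen on an aromatic carbon, the same change at the same kind of place, this time made on the core of compound 3, which differs from the core of compound 1 by hydroxy in place of hydrogen on an aromatic carbon. Since the earlier instance of this change produced only a 1.3-fold lower number from compound 1 to compound 2 (0.12 log units; within the scatter), the step expected from it here is a 1.3-fold lower number from compound 3 to compound 4 (0.11 log units; within the scatter), again within the scatter. On that basis compound 4 is estimated to give 5400 nM in this assay. The expected range for compound 4 runs from 2700 nM to 10800 nM.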

Compound 4, half-maximal inhibitory concentration: 3340 nM
Estimate against measurement, compound 4: 1.6-fold (0.21 log units) above, and the stated range covers the measured number.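

In this assay, turning the 4-chlorophenyl into a 2,4-dichlorophenyl on the hydroxy-bearing core gives a 2.1-fold lower number from compound 3 to compound 4 (0.32 log units; beyond the scatter), a modest step, whereas the same change on the core without the hydroxy stayed within the scatter, yet the two steps cannot be told apart: the same change on two cores in this assay, a 1.3-fold lower number (0.12 log units; within the scatter) from compound 1 to compound 2 and a 2.1-fold lower number (0.32 log units; beyond the scatter) from compound 3 to compound 4, 1.6-fold (0.20 log units) apart, within the scatter of two such steps. The hydroxy change reads the same way, giving a 1.6-fold lower number from compound 2 to compound 4 (0.20 log units; within the scatter) on the dichlorophenyl core, and this step also cannot be separated from its earlier counterpart: the same change on two cores in this assay, a 1.0-fold higher number (0.00 log units; within the scatter) from compound 1 to compound 3 and a 1.6-fold lower number (0.20 log units; within the scatter) from compound 2 to compound 4, 1.6-fold (0.20 log units) apart, within the scatter of two such steps. Both changes are therefore consistent with carrying from one core to the other, but the data do not show that either step has exactly the same size on both cores, nor that the chloro step is truly larger when the hydroxy is present, and two cores are too few to support a rule for the wider series.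

As far as these compounds go, all four compounds keep the same ether chain, so it remains open how a longer chain or a carboxylic acid in its place would behave in this assay. From the compounds shown here alone, it also remains open whether a fluoro, a methoxy or an amine in place of the added chloro would give a step of similar size, or whether it would carry between these two cores in the same way.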